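This account rests on a few compounds, and the source may have more. Where it says the series, first, only, none or still open, it means among the compounds named here.

Measured so far:
- compound 1, `Cc1cc(CO)nc(NNC(=O)Nc2cc(Cl)nc(Cl)c2)c1`: > 6600 nM
- compound 2, `Cc1cc(NNC(=O)Nc2cc(Cl)nc(Cl)c2)ncc1-c1ccn(C)n1`: 4000 nM
- compound 3, `CCOc1cc(NC(=O)NCc2cc(C)c(-c3cn(C)nc3C(F)(F)F)nn2)cc(C#N)n1`: 11000 nM

All three were tested in a functional assay on CHO cells for antagonist activity at sphingosine 1-phosphate receptor 2 (Homo sapiens), read by fluorescence and calcium flux, with a stated time of 3 min; on this read-out higher numbers stand for weaker inhibition and lower numbers for stronger inhibition. For compound 1 the value > 6600 nM is a limit of the assay, not a number, as noted in the limit of > 6600 nM in this assay, at which 1 of the 3 values shown sits. Among the two real numbers, compound 3 gives 11000 nM, the higher of the two, and compound 2 gives 4000 nM; the gap between them lies beyond the usual scatter, so compound 3 is the weaker of these two. Among the compounds with values here, compounds 2 and 3 differ in several places at once, so their pair offers no single step to learn from.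

Compound 4, `CCOc1nc(C#N)cc(NC(=O)NCc2cc(C)c(-c3cn(C)nc3C(F)(F)F)nn2)c1C`, has not yet been measured. It differs from compound 3 by one change, (methyl in place of hydrogen on an aromatic carbon). Within the data shown here, no measured pair shows what such a change does, so the plain expectation is a step of no change at the digits printed from compound 3 to compound 4 (within the scatter) of little size, within the scatter, in no clear direction. Compound 4 is therefore expected to give about 11000 nM, likely between 4000 nM and 30000 nM.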

Compound 4, half-maximal inhibitory concentration: 7100 nM
Compound 4: the middle estimate sits 1.5-fold (0.19 log units) above what was measured; the measured number falls inside the stated range.
By their numbers in this assay, from the lowest: compounds 2, 4 and 3 (each within the scatter of the next, the first and the last beyond it).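

In this assay, within the data shown here, there is a 1.5-fold lower number from compound 3 to compound 4 (0.19 log units; within the scatter) and this is the first step where only one place differs. It shows that methyl in place of hydrogen can be carried on this aromatic carbon, ortho to a large group and to an ethoxy group and para to a cyano group, while the numbers for the two compounds stay indistinguishable. Nothing measured here offers a reason for this result.

From the compounds shown here alone, it stays open whether a longer chain such as propyl, an amine or a chlorine atom on this same carbon would also leave the number where it is. One step also cannot say whether methyl would behave the same way on the different core of compound 2.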